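Indole-pyran dicarbonitriles: expected read-out for compound 4

The source may hold more compounds than are shown below. What is called first, only, known or untested is meant among the compounds shown, and "the series" means these compounds.

Measured compounds:
- compound 1 `COc1cc(Br)c(C2C(C#N)=C(N)OC(c3c[nH]c4ccccc34)=C2C#N)cc1OC`: 20.5%
- compound 2 `N#CC1=C(N)OC(c2c[nH]c3ccccc23)=C(C#N)C1c1ccc(Br)cc1`: 14.6%
- compound 3 `N#CC1=C(N)OC(c2c[nH]c3ccccc23)=C(C#N)C1c1ccc2ccccc2c1`: "not active" (no number reported), without a number

In a functional assay, tested at 100 ug/mL (on this read-out higher numbers stand for a stronger effect at the one concentration tested and lower numbers for a weaker effect), compound 1 gives 20.5% and compound 2 gives 14.6%; the gap between these two values lies within the usual scatter, so neither is set above the other. Compound 3 stands lowest on this read-out only in the sense that it was reported as "not active" (no number reported) with no number attached, so its distance to compound 1 and compound 2 cannot be given.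

Compound 4 `CN(C)c1ccc(C2C(C#N)=C(N)OC(c3c[nH]c4ccccc34)=C2C#N)cc1` differs from compound 3 in one place: 4-(dimethylamino)phenyl in place of naphthalen-2-yl on a saturated ring carbon. Within the data shown here, no step between measured compounds carries this kind of change, so nothing points to a shift beyond the scatter in this assay in either direction; the whole set sits low, and compound 4 is expected to stay in that low band. In this assay compound 4 is estimated at 15%, with a range from 0% to 35%, and a fair chance that it is again reported only as not active.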

Compound 4, a percentage reported as activity, at one concentration (the size of the read-out at that concentration, not a potency): 18.5%
For compound 4 the middle estimate is 3.5 percentage points below the measured one, within the range that was stated.
By their numbers in this assay, from the lowest: compounds 2, 4 and 1 (each within the scatter of the next).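

In this assay the series gains its first readable step at the aryl group on the saturated ring carbon: dimethylamino in place of bromo on an aromatic carbon gives a number 3.9 percentage points higher from compound 2 to compound 4 (within the scatter), so this exchange leaves the read-out within the scatter. Compound 4, with 4-(dimethylamino)phenyl, gives 18.5%, whereas compound 3, with naphthalen-2-yl, was reported only as not active, so steps to compound 3 cannot be read. Nothing at hand bears on why the exchange of bromo for dimethylamino leaves the read-out within the scatter.

Open, from the compounds shown here alone, is whether a carboxylic acid or a morpholine ring on that aromatic carbon would move the read-out beyond the scatter. Also open, going by these compounds, is what a change at the 1H-indol-3-yl group would do, with the aryl group held fixed.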